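Swapping 4-chlorophenyl for phenethyl on a sulfur

This account rests on a few compounds, and the source may have more. Where it says the series, first, only, none or still open, it means among the compounds named here.

Measured so far in a functional assay on HeLa cells (Homo sapiens) for inhibition, read by CCK-8 assay, with a stated time of 72 h, tested at 2 uM (a lower number here means less inhibition of growth, a higher number more inhibition of growth at the concentration tested), are three compounds:
- compound 1 `Nc1ccccc1NC(=O)/C=C/c1ccc(CSc2ccc(Cl)cc2)cc1` with 1.94%
- compound 2 `CCc1ccc(SCc2ccc(C(=O)Nc3ccccc3N)cc2)cc1` with 30.8%
- compound 3 `Nc1ccccc1NC(=O)c1ccc(CSc2cccc(F)c2)cc1` with 22.5%

In this assay compound 1 gives 1.94% and is the lowest of the three. Its gaps to compound 3 and to compound 2 both lie beyond the usual scatter.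

Among the compounds with values here, the next compound, compound 4 `Nc1ccccc1NC(=O)/C=C/c1ccc(CSCCc2ccccc2)cc1`, keeps the core of compound 1 and carries phenethyl in place of 4-chlorophenyl on a sulfur as its only change.

Within the data shown here, one measured step bears on this, since it also exchanges the group on the sulfur: a number 8.3 percentage points lower from compound 2 to compound 3 (within the scatter) for 3-fluorophenyl in place of 4-ethylphenyl. Among the measured compounds shown here, that step lies within the scatter, but it was taken on a core other than that of compound 1, and no measured compound carries phenethyl. The evidence is therefore thin, and no step beyond the scatter is expected. The estimated change is a number 6.1 percentage points higher from compound 1 to compound 4 (within the scatter) and remains uncertain.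

For compound 4 the expected value is 8% with an estimated range from 0% to 25% in this assay as the likely span.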

Compound 4, percent growth inhibition at one concentration: 0.19%
For compound 4 the middle estimate is 7.8 percentage points above the measured one; measured number inside the range.
By their numbers in this assay, from the lowest: compounds 4 and 1 (each within the scatter of the next); then compounds 3 and 2 (each within the scatter of the next).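

In this assay, the step on the core of compound 1 is a number 1.8 percentage points lower from compound 1 to compound 4 (within the scatter), so phenethyl and 4-chlorophenyl on this sulfur cannot be told apart in this read-out, even though a saturated chain now separates the ring from the sulfur. This is the first exchange shown on that core, and it joins a number 8.3 percentage points lower from compound 2 to compound 3 (within the scatter), taken on another core, as a second exchange on the sulfur that stays within the scatter; no compound shown goes against this, though two steps make a narrow base. Nothing available explains why the exchange leaves the number where it is.

Going by these compounds, it remains open whether phenethyl would behave the same way on the core of compound 2 and compound 3, where the numbers give more room for a fall than compound 1 with 1.94% and compound 4 with 0.19%. Also open, on these data alone, is whether a group such as an amine, a carboxylic acid or a longer chain ending in a phenyl ring, placed on this sulfur, would move the number on the core of compound 1 beyond the scatter.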